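Phenoxy in place of pentan-3-yl: expected permeability gain

The compounds below may be only part of what the source reports. "The series", "measured", "known", "first", "only" and "open" are said of these compounds alone.

Measured compounds:
compound 1 `CC(C)(C)c1ccc(Oc2ccc3c(NCCCNCc4ccco4)ccnc3c2)cc1`, 317 10^-6 cm/s
compound 2 `CCC(CC)c1ccc2c(NCCCNCc3cc(F)ccc3OC)ccnc2c1`, 23 10^-6 cm/s
compound 3 `CCC(CC)c1ccc2c(NCCCNCc3ccco3)ccnc2c1`, 23 10^-6 cm/s

In an ADME assay for permeability, using PAMPA, with a stated time of 30 min, at pH 7.4 (on this read-out higher numbers stand for higher permeability and lower numbers for lower permeability), compound 2 gives 23 10^-6 cm/s. That puts compound 2 level with compound 3 at the digits shown, the two together the lowest of the three numbers, while compound 1 stands a long way higher at 317 10^-6 cm/s. Compound 4 `COc1ccc(F)cc1CNCCCNc1ccnc2cc(Oc3ccccc3)ccc12` has not yet been measured. It differs from compound 2 as follows: phenoxy in place of pentan-3-yl on an aromatic carbon. For the measured compounds named here, the only step recorded in one place, no change at the digits printed from compound 2 to compound 3 (within the scatter), concerns the other end of the molecule and shows that swapping the group on the chain carbon bound to the amine nitrogen leaves the read-out unchanged within the scatter; it does not bear directly on the change made here. Going by the values given here, no single-place step covers the exchange of pentan-3-yl for phenoxy. Among the compounds with values here, what can be said is that compound 1, the one compound whose core carries an oxygen-linked ring rather than a branched alkyl chain, sits far above compound 2 and compound 3. On that basis compound 4 is expected to move upward, with a 5.2-fold higher number from compound 2 to compound 4 (0.72 log units; beyond the scatter) as the estimated step. The estimate for compound 4 in this assay is 120 10^-6 cm/s, ranging from 40 10^-6 cm/s to 350 10^-6 cm/s.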

Compound 4, apparent permeability: 317 10^-6 cm/s
For compound 4 the middle estimate is 2.6-fold (0.42 log units) below the measured one, and the stated range covers the measured number.
By their numbers in this assay, from the lowest: compounds 2 and 3 (each within the scatter of the next); then compounds 1 and 4 (each within the scatter of the next).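

In this assay, phenoxy in place of pentan-3-yl on an aromatic carbon gives a 14-fold higher number from compound 2 to compound 4 (1.14 log units; beyond the scatter), the first step recorded at this position. The change at the other end of the molecule gave no change at the digits printed from compound 2 to compound 3 (within the scatter), so among the steps shown, this position is the one where a single exchange moves the read-out beyond the scatter. Nothing shown here accounts for the size of this step.

From the compounds shown here alone, this one step cannot separate the contribution of the oxygen from that of the aromatic ring within phenoxy, and what a phenyl or methoxy group would give on the same carbon remains open. Going by these compounds, it is also open whether a step of this size would appear with furan-2-yl in place of 5-fluoro-2-methoxyphenyl on the chain.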